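Fluoro to Nitro: Expected Effect on Amylase Inhibition

The source may hold more compounds than are shown below. What is called first, only, known or untested is meant among the compounds shown, and "the series" means these compounds.

Compound 1 `Oc1c(Cl)cc(Cl)cc1-c1nc2cc(F)ccc2[nH]1`: 2870 nM in an assay for inhibition of Alpha amylase (Homo sapiens), with a stated time of 10 min; a lower number here means a stronger inhibitor, a higher number a weaker inhibitor
Compound 2 `Oc1c(Br)cc(Cl)cc1-c1nc2cc(F)ccc2[nH]1`: 2860 nM in this assay
Compound 3 `COc1ccc(Br)c(-c2nc3cc([N+](=O)[O-])ccc3[nH]2)c1O`: 2290 nM in this assay

Among these three, compound 2 stands second highest, and both neighbours lie within the scatter of it: the step of a 1.0-fold lower number from compound 1 to compound 2 (0.00 log units; within the scatter) is flat, and compound 3 sits within the scatter as well. Compound 4 `O=[N+]([O-])c1ccc2[nH]c(-c3cc(Cl)cc(Br)c3O)nc2c1` differs from compound 2 by nitro in place of fluoro on an aromatic carbon. Going by the values given here, no measured step tests this exact change. Among the compounds with values here, the only measured step, a 1.0-fold lower number from compound 1 to compound 2 (0.00 log units; within the scatter), concerns a different swap and was flat. Compound 3 carries a nitro group but also differs elsewhere, so its value alongside that of compound 2 shows only that the two lie within the scatter. The expected step of a 1.1-fold lower number from compound 2 to compound 4 (0.06 log units; within the scatter) is therefore no change beyond the scatter. Compound 4 is estimated at 2500 nM, with a range from 1100 nM to 5700 nM.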

Compound 4, half-maximal inhibitory concentration: 2870 nM
For compound 4 the middle estimate is 1.1-fold (0.06 log units) below the measured one, within the range that was stated.
By their numbers in this assay, from the lowest: compounds 3, 2, 1 and 4 (each within the scatter of the next).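

Going by these compounds alone, the step of a 1.0-fold higher number from compound 2 to compound 4 (0.00 log units; within the scatter) in this assay is the first direct test of this change on this aromatic carbon. It shows that nitro, with three heavy atoms and two hydrogen-bond acceptors, can take the place of a single fluorine without a difference that stands out from the scatter. No supporting data are available to explain this flat result. As far as these compounds go, whether an amine or a carboxylic acid on this carbon would give a value beyond the scatter remains open, as does whether nitro and fluoro would also match with different groups elsewhere on the shared core.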